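This account rests on a few compounds, and the source may have more. Where it says the series, first, only, none or still open, it means among the compounds named here.

The study compares three compounds in an assay on Sf9 cells for inhibition of Amine oxidase [flavin-containing] B (Homo sapiens), with stated times of 15 min and 60 min; a lower number here means a stronger inhibitor, a higher number a weaker inhibitor. Compound 1, `C#CCN(Cc1ccc(OCc2cccc(F)c2)cc1F)[C@@H](C)C(N)=O`, gives 93 nM in this assay. Compound 2, `Cc1cc(OCc2cccc(F)c2)ccc1CN1CC[C@H]1C(N)=O`, gives 258 nM, and compound 3, `NC(=O)C1CN(Cc2ccc(OCc3cccc(F)c3)cc2)C1`, gives 1420 nM. Compound 1 thus stands at the lowest of the three numbers; its nearest neighbour is compound 2, whose number is higher by a margin beyond the usual scatter, and compound 3 lies furthest from it, also well beyond the scatter. Compounds 2 and 3 each differ from compound 1 in more than one place, so their numbers alone say nothing about any single change.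

Compound 4, `C#CCN(Cc1ccc(OCc2cccc(F)c2)cc1)[C@@H](C)C(N)=O`, has not yet been measured in this assay. It arises from compound 1 by one change: hydrogen in place of fluoro on an aromatic carbon. The site is an aromatic carbon of a six-membered aromatic ring of carbon only, ortho to a large group. Within the data shown here, no measured pair in this set isolates that change, so there is no direct precedent for its size. The step is expected to be small, most likely toward a somewhat higher number, and a result within the scatter would not surprise. Compound 4 is expected to give 160 nM, within a range from 60 nM to 450 nM. The expected step is a 1.7-fold higher number from compound 1 to compound 4 (0.24 log units; within the scatter).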

Compound 4, half-maximal inhibitory concentration: 530 nM
Compound 4: the middle estimate sits 3.3-fold (0.52 log units) below what was measured; the measured number lies above the stated range.
By their numbers in this assay, from the lowest: compound 1; then compound 2; then compound 4; then compound 3.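

In this assay, among these compounds, the exchange of fluoro for hydrogen is the first change in this set that can be read on its own, and it gives a 5.7-fold higher number from compound 1 to compound 4 (0.76 log units; beyond the scatter), a step beyond the scatter. The site on the aromatic carbon ortho to a large group is therefore not indifferent to this substitution: the loss of one fluorine, with no ring, hydrogen-bond donor, hydrogen-bond acceptor or net charge involved, is enough to move the number by this margin. The compounds and data available offer no independent information that would explain the size of this step.

Among the compounds shown here, it remains open whether a chloro, methyl or methoxy group on the same aromatic carbon would keep the number near that of compound 1 or move it further, since fluoro and hydrogen are the only two groups compared at this site. From the compounds shown here alone, it is also open whether the same exchange would give a step of similar size on the structures of compound 2 and compound 3, which differ from compound 1 in more than one place.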